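Swapping a Chloro for a Bromo on the Benzyl Ring

The source may hold more compounds than are shown below. What is called first, only, known or untested is meant among the compounds shown, and "the series" means these compounds.

Three measured compounds share one core and differ only in the benzyl group attached to the aromatic nitrogen. Compound 1 `O=[N+]([O-])c1cc(-c2nnn(Cc3ccccc3)n2)cc([N+](=O)[O-])c1` carries an unsubstituted benzyl group and in an ADME assay on CHO-K1 cells (Cricetulus griseus) for cytotoxicity, read by MTT assay, with a stated time of 24 h (a lower number here means a stronger inhibitor, a higher number a weaker inhibitor), compound 1 gives 150000 nM. Compound 2 `O=[N+]([O-])c1cc(-c2nnn(Cc3ccc(Cl)cc3)n2)cc([N+](=O)[O-])c1` gives 170000 nM, and compound 3 `O=[N+]([O-])c1cc(-c2nnn(Cc3cccc(Cl)c3)n2)cc([N+](=O)[O-])c1` gives 27000 nM. Compound 3 stands lowest of the three: the steps of a 5.6-fold lower number from compound 1 to compound 3 (0.74 log units; beyond the scatter) and a 6.3-fold lower number from compound 2 to compound 3 (0.80 log units; beyond the scatter) are both beyond the scatter, while the step of a 1.1-fold higher number from compound 1 to compound 2 (0.05 log units; within the scatter) is within it.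

Compound 4 `O=[N+]([O-])c1cc(-c2nnn(Cc3ccc(Br)cc3)n2)cc([N+](=O)[O-])c1` is the next compound. The change from compound 3 to compound 4 is 4-bromophenyl in place of 3-chlorophenyl on a saturated chain carbon bound to an aromatic nitrogen. Going by the values given here, two measured steps bear on it. Moving the chloro from the 4-position to the 3-position, in the step from compound 2 to compound 3, lowered the number beyond the scatter; the step from compound 1 to compound 2 shows that a chloro at the 4-position left the number within the scatter of the unsubstituted benzyl. Among the compounds with values here, no measured compound carries a bromo, so that part of the change has no precedent here.

Moving the halogen back to the 4-position is therefore expected to raise the number, and compound 4 is expected to fall near compound 1 and compound 2, with an estimated step of a 4.8-fold higher number from compound 3 to compound 4 (0.68 log units; beyond the scatter). For compound 4 the estimate in this assay is 130000 nM, with a range from 50000 nM to 320000 nM.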

Compound 4, half-maximal inhibitory concentration: 55000 nM
Compound 4: the middle estimate sits 2.4-fold (0.37 log units) above what was measured; the measured number falls inside the stated range.
By their numbers in this assay, from the lowest: compound 3; then compound 4; then compounds 1 and 2 (each within the scatter of the next).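

Bromo and chloro are not interchangeable on this benzyl ring in this assay: the chloro of compound 2 stayed within the scatter of the unsubstituted benzyl group, yet bromo in its place gives a 3.1-fold lower number from compound 2 to compound 4 (0.49 log units; beyond the scatter). Bromo in place of hydrogen gives a 2.7-fold lower number from compound 1 to compound 4 (0.44 log units; beyond the scatter), so here a halogen at this ring position does shift the number, depending on which halogen it is. The 3-chlorobenzyl group still holds the lowest number, with a 2.0-fold higher number from compound 3 to compound 4 (0.31 log units; beyond the scatter), but this step changes the halogen and its ring position together, so it cannot credit either one alone.

Nothing available explains why the two halogens differ. Going by these compounds, whether bromo in place of chloro would keep the low number of compound 3 stays open, as does the effect of a fluoro or an amine on the benzyl ring.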